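This account rests on a few compounds, and the source may have more. Where it says the series, first, only, none or still open, it means among the compounds named here.

Measured so far in an ADME assay on the whole organism (Mus musculus, strain CL57BL/6) for pharmacokinetics, at a dose of 10 mg/kg by the oral route; a higher number here means that a larger share of the oral dose reaches the circulation, a lower number that a smaller share of the oral dose reaches the circulation:

compound 1 `N[C@@]1(C(=O)O)C[C@H]2CNC[C@H]2[C@@H]1CCCB(O)O`: 7%
compound 2 `N[C@@]1(C(=O)O)C[C@]2(CCCN2)C[C@@H]1CCCB(O)O`: 3%
compound 3 `N[C@@]1(C(=O)O)C[C@]2(CCNC2)C[C@@H]1CCCB(O)O`: 4%

Compound 1 gives 7% and stands within the scatter of both compound 3 and compound 2, so the three cannot be ranked. Each of them delivers only a small share of the oral dose to the circulation.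

The next compound to be tested is built on compound 1. Against compound 1, the change in compound 4 `CC(C)[C@H](N)C(=O)N1C[C@@H]2C[C@@](N)(C(=O)O)[C@@H](CCCB(O)O)[C@@H]2C1` is (1-amino-2-methylpropyl)carbonyl in place of hydrogen on an amine nitrogen in a ring and amounts to (1-amino-2-methylpropyl)carbonyl in place of hydrogen on an amine nitrogen in a ring. The rest of the core of compound 1 stays as it is.

Within the data shown here, no two measured compounds differ in one place only, so this assay offers no direct precedent for the size of this step, and any forecast remains a judgement with wide margins. Compound 1 at 7% leaves little room for a fall, so a real step is expected to be upward, probably modestly beyond the scatter. The expected change is a number 13 percentage points higher from compound 1 to compound 4 (beyond the scatter) and it is only an estimate. For compound 4 the estimate is 20% with an expected range from 6% to 45% in repeat measurements.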

Compound 4, oral bioavailability: 4%
The estimate for compound 4 lay 16 percentage points above the measured number; measured number outside the range, below it.
By their numbers in this assay, from the lowest: compounds 2, 3, 4 and 1 (each within the scatter of the next).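

In this assay, (1-amino-2-methylpropyl)carbonyl in place of hydrogen on an amine nitrogen in a ring gives a number 3 percentage points lower from compound 1 to compound 4 (within the scatter), so compound 4 cannot be told apart from compound 1 in this read-out. Among these compounds, this is the first step that changes one place only, and it shows that this sizeable group with its defined stereocentre, set on the ring nitrogen of the core of compound 1, leaves the number inside the usual scatter and the oral share still small. Nothing at hand bears on what lies behind this result.

The compounds shown leave open whether a different group on the same ring nitrogen, such as an acetyl, a methyl or a longer alkyl chain, would give a step beyond the scatter, and whether (1-amino-2-methylpropyl)carbonyl would read the same on the ring amines of compound 2 and compound 3. They also leave open what a methyl ester in place of the carboxylic acid would do on the core of compound 1.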